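A few compounds are considered here, and "the series" means these few. Any claim that something is new, unique, unknown or untested is made for them only; others in the source may bear on it.

Measured so far:

compound 1, `CCn1c(CN2CCN(c3ncc(Cl)cn3)CC2)nc2ccccc21` — 158 nM
compound 2, `Cn1c(CN2CCN(c3ccc(Cl)cc3F)CC2)nc2ccccc21` — 126 nM

Both numbers come from an assay on CHO cells with metabotropic glutamate receptor 2 (Homo sapiens) as the target, read by FLIPR; on this read-out lower numbers stand for an effect already at smaller amounts and higher numbers for an effect only at larger amounts of compound. In this assay, going by the values given here, compound 1 gives 158 nM, and compound 2 gives 126 nM; the two values lie within the usual scatter of each other, so neither compound can be placed ahead of the other on this evidence, and no single-point step between the two has been measured.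

The compound still to be tested is compound 3, `Clc1cnc(N2CCN(Cc3nc4ccccc4n3Cc3ccccc3)CC2)nc1`. It is built from compound 1 by one change: phenyl in place of methyl on a saturated chain carbon bound to an aromatic nitrogen. Cut one bond further out, the same difference reads ethyl to benzyl, so the chain on the aromatic nitrogen of the shared core grows by a six-membered aromatic ring of carbon only while donors, acceptors and charge stay unchanged.

Among the compounds with values here, no measured pair shows what this kind of change does here, so the expectation rests on compound 1 alone. A small shift toward a higher number, that is an effect only at somewhat larger amounts, is expected, though a result within the scatter would not be surprising. The step from compound 1 to compound 3 is estimated as a 1.6-fold higher number from compound 1 to compound 3 (0.20 log units; within the scatter). For compound 3 the expected value in this assay is 250 nM, with a range from 80 nM to 800 nM.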

Compound 3, half-maximal effective concentration: 126 nM
Compound 3: the middle estimate sits 2.0-fold (0.30 log units) above what was measured; measured number inside the range.
By their numbers in this assay, from the lowest: compounds 2, 3 and 1 (each within the scatter of the next).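

In this assay the change of ethyl to benzyl on the aromatic nitrogen gives a 1.3-fold lower number from compound 1 to compound 3 (0.10 log units; within the scatter) and is the first step shown that alters a single place. It shows that this position can carry a six-membered aromatic ring of carbon only, in place of the methyl at the end of the chain, without a change that rises above the scatter of repeated measurements. No measurement shown gives a reason for this result.

As far as these compounds go, what remains open is how far this tolerance extends: a single pair cannot show whether a longer chain such as butyl, a chain ending in an amine or a carboxylic acid, or a benzyl carrying a methoxy group on its ring would also stay within the scatter of compound 1. From the compounds shown here alone, it is also open whether benzyl would behave the same way on a compound carrying the other end of compound 2, and whether any group at this position could move the number beyond the scatter in either direction.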